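The source may report more compounds than this note shows. Statements on the series, on what has been measured and on what is new or still open speak of the compounds shown alone.

Measured so far in an ADME assay on the whole organism (Mus musculus, strain CD-1) for pharmacokinetics, at a dose of 10 mg/kg by the oral route; on this read-out higher numbers stand for higher oral bioavailability and lower numbers for lower oral bioavailability:
- Compound 1 `CCOc1cc([C@](O)(CCN(C)C)[C@H](c2cccc(C)c2)c2cc3cc(Br)ccc3nc2OC)cc(OC)n1`: 65%
- Compound 2 `CCOc1cc([C@](O)(CCN(C)C)[C@@H](c2cc3cc(Br)ccc3nc2OC)c2ccnc(OC)c2OC)cc(OC)n1`: 70%

For the measured compounds named here, with only these two numbers, the single measured step is a number 5 percentage points higher from compound 1 to compound 2 (within the scatter). Going by the values given here, compound 2 therefore cannot be told apart from the only other measured compound.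

The next compound is compound 3 `COc1cc([C@](O)(CCN(C)C)[C@@H](c2cc3cc(Br)ccc3nc2OC)c2ccnc(OC)c2OC)cc(OC(F)F)n1`. It keeps all of compound 2 except for one group: difluoromethyl in place of ethyl on an oxygen on an aromatic ring. In other words, ethoxy becomes difluoromethoxy.

Among the compounds with values here, the one measured step swapped a different group, so it offers no direct guide to this change. Within the data shown here, the only anchor is compound 2 at 70%, and no shift beyond the scatter is expected in either direction. The expected change is a number 5 percentage points lower from compound 2 to compound 3 (within the scatter). For compound 3, the estimate in this assay is 65%, with an expected range from 42% to 85%.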

Compound 3, oral bioavailability: 50%
Beside the measured number, compound 3's estimate is 15 percentage points above it; measured number inside the range.
By their numbers in this assay, from the lowest: compound 3; then compounds 1 and 2 (each within the scatter of the next).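

In this assay, replacing ethyl with difluoromethyl on an oxygen on an aromatic ring gives a number 20 percentage points lower from compound 2 to compound 3 (beyond the scatter), the only step shown that lies beyond the scatter. This position therefore affects the read-out, at least in this pair: the group on this oxygen cannot be exchanged freely without a measurable change. Nothing measured alongside the result points to an explanation for the drop.

On these data alone, it remains open whether the lower number is tied to the fluorine atoms or simply to the loss of ethyl, a question that a methyl or a trifluoromethyl on the same oxygen could help to answer. As far as these compounds go, it is also open whether the same swap would give a step of similar size on the core of compound 1.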